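Benzyl carbamate series: removing the dichloro substitution

The source may hold more compounds than are shown below. What is called first, only, known or untested is meant among the compounds shown, and "the series" means these compounds.

The shared core of the series is shown by compound 1 `O=C(OCc1ccc(Cl)c(Cl)c1)N(c1ccccc1)C1CN2CCC1CC2` and compound 2 `O=C(OCCCc1ccc(F)c(F)c1)N(c1ccccc1)C1CN2CCC1CC2`. In an assay on CHO cells for displacement of a labelled ligand from muscarinic acetylcholine receptor M5 (Homo sapiens), read by scintillation counting, with a stated time of 2 h (a higher number here means a weaker inhibitor, a lower number a stronger inhibitor), compound 1 gives 60 nM, and in this assay compound 2 gives 100 nM; the two numbers sit within the scatter of each other, so neither can be placed ahead of the other. Among the measured compounds shown here, no step between measured compounds is available, so the effect of substitution on the benzyl ring remains unmeasured.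

Compound 3 `O=C(OCc1ccccc1)N(c1ccccc1)C1CN2CCC1CC2` is the next point: phenyl in place of 3,4-dichlorophenyl on a saturated chain carbon bound to an oxygen next to a carbonyl group. For compound 3 in this assay, a modest rise in the number, beyond the scatter but not large, is expected, a 3.0-fold higher number from compound 1 to compound 3 (0.48 log units; beyond the scatter). The estimate for compound 3 in this assay is 180 nM, with a range from 60 nM to 600 nM; a result within the scatter of compound 1 would not be surprising.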

Compound 3, inhibition constant: 150 nM
Beside the measured number, compound 3's estimate is 1.2-fold (0.08 log units) above it; the range from low to high includes it.
By their numbers in this assay, from the lowest: compounds 1, 2 and 3 (each within the scatter of the next, the first and the last beyond it).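

In this assay, among the compounds shown here, phenyl in place of 3,4-dichlorophenyl on a saturated chain carbon bound to an oxygen next to a carbonyl group gives a 2.5-fold higher number from compound 1 to compound 3 (0.40 log units; beyond the scatter), the first single-place step. The two chlorines therefore make a modest difference at this position, and they are not needed for measurable binding: without them, compound 3 still gives 150 nM. No available evidence bears on the origin of this step.

Whether one chlorine alone, as in 4-chlorophenyl, accounts for the step remains open, as does the effect of a methoxy group or an amine on the phenyl. Compound 2 differs from compound 1 and compound 3 in more than one place, so the effect of its longer chain cannot be separated from that of its two fluorines.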